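This account rests on a few compounds, and the source may have more. Where it says the series, first, only, none or still open, it means among the compounds named here.

Measured compounds:
compound 1 `COc1ccc(-c2cc(/C=C/C(=O)c3ccc(N)cc3)[nH]n2)cc1` — in a functional assay on SNB-19 cells (Homo sapiens) for inhibition, read by sulforhodamine B assay, with a stated time of 48 h (a lower number here means a stronger inhibitor of growth, a higher number a weaker inhibitor of growth), compound 1 gives 2290 nM
compound 2 `COc1cc(-c2cc(/C=C/C(=O)c3ccc(N)cc3)[nH]n2)cc(OC)c1OC` — in this assay compound 2 gives 2340 nM
compound 3 `COc1ccc(C(=O)/C=C/c2cc(-c3cc(OC)c(OC)c(OC)c3)n[nH]2)cc1OC` — in this assay compound 3 gives 1420 nM

All three numbers in this assay lie close together. Compound 2 stands at the upper edge of them: compound 1 gives a number within the scatter of compound 2, and a 1.6-fold lower number from compound 2 to compound 3 (0.22 log units; within the scatter) is also within the scatter, so none of the three can be set apart from the others.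

Compound 4 `COc1ccc(-c2cc(/C=C/C(=O)c3ccc(N)cc3)[nH]n2)cc1OC` has not yet been measured in this assay. It differs from compound 2 in one place: hydrogen in place of methoxy on an aromatic carbon. Going by the values given here, no measured step makes exactly this change. a 1.6-fold lower number from compound 2 to compound 3 (0.22 log units; within the scatter) concerns a different part of the molecule, the group on the carbonyl carbon, and was within the scatter. Compound 1 and compound 2 differ on the same ring by more than one methoxy group, and compound 1 gives 2290 nM while compound 2 gives 2340 nM, two numbers within the scatter of each other. Taking one methoxy group away from compound 2 is therefore expected to give no step beyond the scatter, a 1.0-fold lower number from compound 2 to compound 4 (0.01 log units; within the scatter). Compound 4 is estimated at 2300 nM, within a range from 1100 nM to 4800 nM.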

Compound 4, concentration for 50% growth inhibition: 4360 nM
The estimate for compound 4 lay 1.9-fold (0.28 log units) below the measured number; measured number inside the range.
By their numbers in this assay, from the lowest: compounds 3, 1, 2 and 4 (each within the scatter of the next, the first and the last beyond it).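

In this assay, a single methoxy group on this ring can now be read on its own, from both sides: taking it off gives a 1.9-fold higher number from compound 2 to compound 4 (0.27 log units; within the scatter), and adding it gives a 1.9-fold higher number from compound 1 to compound 4 (0.28 log units; within the scatter). The earlier compounds shown here offered only compound 1 and compound 2, which differ by more than one methoxy group, whereas compound 4 supplies the intermediate case and splits that difference into two single changes, neither of which can be told apart from repeat-measurement noise. Swapping hydrogen and methoxy at this place, ortho to a methoxy group, therefore shows no effect on growth inhibition that these numbers can support, and nothing available explains the small differences that do appear.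

The compounds shown leave open whether a different group at this place, such as a hydroxy group, a chlorine atom or a longer ether like ethoxy, would move the number beyond the scatter. They also leave open how the same methoxy change behaves when the group on the carbonyl carbon is something other than 4-aminophenyl.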